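This account rests on a few compounds, and the source may have more. Where it says the series, first, only, none or still open, it means among the compounds named here.

Measured in a functional assay (muscle tissue) with Cavia porcellus as the target; a higher number here means that more compound is needed for the effect, a lower number that less compound is needed:
- compound 1 `COC(=O)C1=C(C)N=C(C)/C(=C(\O)OC)C1c1cc(C)ccc1C`: 100 nM
- compound 2 `COC(=O)C1=C(C)N=C(C)/C(=C(\O)OC)C1c1c(Cl)cccc1Cl`: 1.91 nM

Of these two numbers, the lower belongs to compound 2, at 1.91 nM. Compound 3 `COC(=O)C1=C(C)N=C(C)/C(=C(\O)OC)C1c1cccc(I)c1` has not yet been measured. It keeps the shared core and changes one group: 3-iodophenyl in place of 2,6-dichlorophenyl on a saturated ring carbon.

For the measured compounds named here, only one measured step bears on this change, and it concerns the same place: a 52-fold lower number from compound 1 to compound 2 (1.72 log units; beyond the scatter). That large step shows that swapping this group can move the number a long way, but neither measured compound carries iodine, so it offers only a rough guide to size. With compound 2 at the low end of the two values, at 1.91 nM, a rise is more likely than a further fall. The expected change is a 10-fold higher number from compound 2 to compound 3 (1.02 log units; beyond the scatter), which would be beyond the scatter yet smaller than the measured step. Compound 3 is estimated at 20 nM, with an expected range of 5 nM to 80 nM.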

Compound 3, half-maximal effective concentration: 41.7 nM
The estimate for compound 3 lay 2.1-fold (0.32 log units) below the measured number, and the stated range covers the measured number.
By their numbers in this assay, from the lowest: compound 2; then compound 3; then compound 1.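

In this assay, the step to the new group is a 22-fold higher number from compound 2 to compound 3 (1.34 log units; beyond the scatter), so the low number of compound 2 does not carry over to every halogen-bearing phenyl group at this saturated ring carbon. The other comparison, a 2.4-fold lower number from compound 1 to compound 3 (0.38 log units; beyond the scatter), is much smaller, which leaves 3-iodophenyl closer to 2,5-dimethylphenyl than to 2,6-dichlorophenyl on this scale. Nothing available here explains why these groups differ.

2,6-Dichlorophenyl and 3-iodophenyl differ in the halogen, in the number of halogen atoms and in where they sit, so these three compounds cannot show which of those changes matters. On these data alone, how an unsubstituted phenyl group, or a phenyl group carrying an amine or a nitrile, would behave at this carbon also remains open.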